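Trimethoxyphenyl amides: varying the halogenated acyl group

This account rests on a few compounds, and the source may have more. Where it says the series, first, only, none or still open, it means among the compounds named here.

Measured so far in a functional assay on KYSE-450 cells (Homo sapiens) for inhibition, read by MTT assay, with a stated time of 48 h; a higher number here means a weaker inhibitor, a lower number a stronger inhibitor:
- compound 1 `COc1ccc(CN(C(=O)CCl)c2cc(OC)c(OC)c(OC)c2)cc1O`: 210 nM
- compound 3 `C/C=C/C(=O)N(Cc1ccc(OC)c(N)c1)c1cc(OC)c(OC)c(OC)c1`: 310 nM
- compound 2 `COc1cc(NCc2cccc(O)c2)cc(OC)c1OC`: 71300 nM

Compound 1 has the lowest number of the three in this assay. Compound 3 lies within the scatter of compound 1, so no order between them can be read. Compound 2, which lacks an acyl group on the nitrogen, sits far beyond the scatter from compound 1.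

Compound 4 `COc1ccc(CN(C(=O)C(C)Br)c2cc(OC)c(OC)c(OC)c2)cc1O` differs from compound 1 in one place: 1-bromoethyl in place of chloromethyl on a carbonyl carbon. Among the compounds with values here, no measured pair covers this change, so the step is estimated rather than derived. A small move towards a higher number is expected, with a 1.9-fold higher number from compound 1 to compound 4 (0.28 log units; within the scatter) plausibly still within the scatter. Compound 4 is estimated at 400 nM in this assay, between 120 nM and 1500 nM.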

Compound 4, half-maximal inhibitory concentration: 160 nM
The estimate for compound 4 lay 2.5-fold (0.40 log units) above the measured number; the measured number falls inside the stated range.
By their numbers in this assay, from the lowest: compounds 4, 1 and 3 (each within the scatter of the next); then compound 2.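

In this assay, within the data shown here, 1-bromoethyl in place of chloromethyl on a carbonyl carbon gives a 1.3-fold lower number from compound 1 to compound 4 (0.12 log units; within the scatter), the first single-place comparison at this position. The two groups cannot be told apart in this read-out, so swapping the halogen and extending the group together leaves the value of the core of compound 1 within the scatter. Nothing available bears on why the two groups read alike.

Open, as far as these compounds go, is how bromomethyl or 1-chloroethyl would read, which would separate the halogen from the added carbon. Also open, from the compounds shown here alone, is how a halogen-free group, such as a propyl chain or an aminomethyl group, would read at this carbonyl on the same core.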